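This account rests on a few compounds, and the source may have more. Where it says the series, first, only, none or still open, it means among the compounds named here.

Of the compounds shown here, three built on one shared core have been measured in a functional assay on HeLa cells (Homo sapiens) for inhibition, read by sulforhodamine B assay; on this read-out lower numbers stand for stronger inhibition and higher numbers for weaker inhibition. Compound 1 `O=C1C=C(Nc2ccc(I)cc2)C(=O)c2c1nc1n2[C@H]2OC[C@@H](O)[C@H]2OC1` gives 4070 nM. Compound 2 `CCCc1ccc(NC2=CC(=O)c3c(nc4n3[C@H]3OC[C@@H](O)[C@H]3OC4)C2=O)cc1` gives 6030 nM. Compound 3 `O=C1C=C(Nc2ccccc2)C(=O)c2c1nc1n2[C@H]2OC[C@@H](O)[C@H]2OC1` gives 5620 nM, the second highest of the three numbers; its nearest neighbour is compound 2 and its furthest is compound 1, and both gaps lie within the scatter, so the three cannot be separated on these data. Among the measured compounds shown here, the only step joining two measured compounds that differ in a single place is a 1.4-fold higher number from compound 1 to compound 3 (0.14 log units; within the scatter), which shows that swapping iodo for hydrogen on the aromatic carbon left the number where it was.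

Compound 4 `COc1ccc(NC2=CC(=O)c3nc4n(c3C2=O)[C@H]2OC[C@@H](O)[C@H]2OC4)cc1` has not yet been measured. It differs from compound 3 by methoxy in place of hydrogen on an aromatic carbon, so the anilino ring again carries a small group at the position that held iodo in compound 1. For the measured compounds named here, that earlier step bears on this change because a 1.4-fold higher number from compound 1 to compound 3 (0.14 log units; within the scatter) stayed within the scatter, and no other measured pair speaks to a methoxy. No step beyond the scatter is therefore expected in this assay, in either direction. Compound 4 is estimated to give about 5600 nM, within a range of 2800 nM to 11000 nM. That estimate means an expected step of a 1.0-fold lower number from compound 3 to compound 4 (0.00 log units; within the scatter).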

Compound 4, half-maximal inhibitory concentration: 4780 nM
Compound 4: the middle estimate sits 1.2-fold (0.07 log units) above what was measured; the range from low to high includes it.
By their numbers in this assay, from the lowest: compounds 1, 4, 3 and 2 (each within the scatter of the next).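

In this assay, methoxy in place of hydrogen on the anilino ring, para to a large group, gives a 1.2-fold lower number from compound 3 to compound 4 (0.07 log units; within the scatter), and methoxy in place of iodo on that same carbon gives a 1.2-fold higher number from compound 1 to compound 4 (0.07 log units; within the scatter). Until now only the swap between iodo and hydrogen could be read at this carbon, whereas these steps add a group of a different kind, one that brings an oxygen and a hydrogen-bond acceptor, and both steps still lie within the scatter, so hydrogen, iodo and methoxy cannot be told apart here on these numbers. No measured evidence is available to explain this result.

The compounds shown leave open whether any group on this carbon can move the number beyond the scatter, for example an amine, a carboxylic acid or a chain longer than methoxy. They also leave open whether methoxy on a different carbon of the same ring would stay as close to the hydrogen compound as it does here.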